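The compounds below may be only part of what the source reports. "The series", "measured", "known", "first", "only" and "open" are said of these compounds alone.

Compound 1 `CNc1nc(NC2(C#N)CCCCC2)nc(N(C)C)n1` gives 276 mL/min/kg
Compound 2 `CNc1nc(NC2(C#N)CCCCC2)nc(SC)n1` gives 579 mL/min/kg

Both numbers come from an ADME assay on microsomes from liver (Rattus norvegicus) for metabolic stability (a higher number here means faster removal of the compound, a lower number slower removal), and are the only ones measured so far. Of the two, compound 2 has the highest number, 579 mL/min/kg, so it is the one removed faster. The next compound, compound 3 `CNc1nc(NC2(C#N)CCCCC2)nc(-n2cnc(C)n2)n1`, shares the core and differs from compound 2 in one place: 3-methyl-1H-1,2,4-triazol-1-yl in place of methylsulfanyl on an aromatic carbon. The new group sits on an aromatic carbon between two ring nitrogen atoms.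

Going by the values given here, only one measured step bears on this change: a 2.1-fold higher number from compound 1 to compound 2 (0.32 log units; beyond the scatter), modest but beyond the scatter, with methylsulfanyl in place of dimethylamino on that same carbon. Like dimethylamino, the entering group is attached through nitrogen, so a move back toward compound 1 at 276 mL/min/kg is the best guess. Among the compounds with values here, one step is thin evidence, however, and no measured compound carries this new group. The expected change is a 2.2-fold lower number from compound 2 to compound 3 (0.35 log units; beyond the scatter), a drop of about the same size as the measured step. For compound 3 the estimated clearance is 260 mL/min/kg, with an expected range from 110 mL/min/kg to 520 mL/min/kg in this assay.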

Compound 3, clearance: > 276 mL/min/kg
Compound 3: only a limit was reported; the forecaster's own chance of this, stated with the estimate: 3%; at least 1.0-fold (0.02 log units) between middle value and limit.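

In this assay compound 3 is reported only as a limit, > 276 mL/min/kg, and not as a number. Putting 3-methyl-1H-1,2,4-triazol-1-yl in place of dimethylamino on this aromatic carbon gives a number no lower from compound 1 to compound 3 (the limit leaves the size open), so this second group attached through nitrogen brings no drop in that comparison. The step from the methylsulfanyl compound cannot be read, and the reading stops at a single value: the limit of > 276 mL/min/kg in this assay, at which 1 of the 3 values shown sits.

From the compounds shown here alone, whether compound 3 stands higher or lower than compound 2 remains open, as does how far the number rises when the triazole group replaces dimethylamino. Also open, going by these compounds, are how a methoxy group or a primary amine on this carbon would read in this assay, and what the methyl on the triazole ring contributes.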